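This account rests on a few compounds, and the source may have more. Where it says the series, first, only, none or still open, it means among the compounds named here.

Values in a functional assay on the whole organism (strain albino) for inhibition, with Rattus norvegicus as the target, read by paw edema, with stated times of 30 min and 3 h, at a dose of 25 mg/kg by the intraperitoneal route (a lower number here means less inhibition, a higher number more inhibition at the dose given (going by the name of the read-out)), for the measured members of the series:

compound 1 `CCOC(=O)c1nn(-c2ccccc2)c(-c2ccc(OC)cc2OC)c1C` — 5.81%
compound 2 `CCOC(=O)c1nn(-c2ccc(Cl)cc2)c(-c2ccc(OC)cc2OC)c1C` — 2.22%
compound 3 `CCOC(=O)c1nn(-c2ccc(Cl)cc2)c(-c2ccc(OC)cc2OC)c1-c1ccccc1` — 15%

Compound 2 stands lowest of the three numbers. Its nearest neighbour is compound 1, and the step of a number 3.6 percentage points lower from compound 1 to compound 2 (within the scatter) lies within the scatter, so the two cannot be ordered. The step to compound 3, a number 12.8 percentage points higher from compound 2 to compound 3 (beyond the scatter), is beyond the scatter and modest; it comes from a phenyl in place of methyl on an aromatic carbon.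

The next compound, compound 4 `COc1ccc(-c2c(C)c(C(=O)O)nn2-c2ccc(Cl)cc2)c(OC)c1`, differs from compound 2 in one place: hydrogen in place of ethyl on an oxygen next to a carbonyl group. Neither measured step touches the ester; the chloro step and the phenyl step both concern aromatic carbons, so nothing measured bears directly on this change. Within the data shown here, with no precedent, the working expectation is no step beyond the scatter in this assay, in either direction, and the estimated step is a number 3.8 percentage points higher from compound 2 to compound 4 (within the scatter).

For compound 4 in this assay the estimate is 6%, with a range from 0% to 18%.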

Compound 4, a percentage reported as inhibition, in the whole organism at one dose (the size of the read-out at that dose, not a potency): 22.8%
Estimate against measurement, compound 4: 16.8 percentage points below; the whole stated range lies below it.
By their numbers in this assay, from the lowest: compounds 2, 1, 3 and 4 (each within the scatter of the next, the first and the last beyond it).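

Among these compounds, the ester position is not silent: with the ethoxycarbonyl to carboxy change, this assay moves by a number 20.6 percentage points higher from compound 2 to compound 4 (beyond the scatter), and this is the first measured change at this position. Like the phenyl step on the shared core, this step lies beyond the scatter, whereas the chloro step does not, so the series now has a second place where a single change registers in the read-out. Nothing at hand explains the step.

Among the compounds shown here, whether a carboxy group gives a similar step without the chloro substituent remains open, since only one pair of compounds speaks to this change. Also open, on these data alone, is how the position responds to groups other than ethoxycarbonyl and carboxy, such as a primary amide, a methyl ester or a longer chain ester.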